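Notes on a mirror-image pair in the series

The compounds below may be only part of what the source reports. "The series", "measured", "known", "first", "only" and "open" are said of these compounds alone.

- compound 1 `C[C@]1(O)C[C@@](c2cccc(C(F)(F)F)c2)([C@H](O)c2ccccn2)C1` gives 317 mL/min/kg
- compound 2 `C[C@@]1(c2ccc(OC(F)(F)F)cc2)C[C@@](O)(c2ccccn2)CO1` gives 333 mL/min/kg

In an ADME assay on liver for metabolic stability, with Liver microsome (Rattus norvegicus) as the target, read by LC-MS, using microsomes, with a stated time of 5 h (on this read-out lower numbers stand for slow clearance and higher numbers for fast clearance), compound 2 stands at 333 mL/min/kg and compound 1 at 317 mL/min/kg with the two numbers within the usual scatter of each other, so neither ranks ahead.

In compound 3 `C[C@]1(c2ccc(OC(F)(F)F)cc2)C[C@](O)(c2ccccn2)CO1` the change from compound 2 is the two compounds have the same atoms and bonds and differ only in configuration as drawn: 2 of 2 stereo elements differ (all stereocentres are inverted: mirror images); a stereocentre at a saturated ring carbon is drawn S in compound 2 and R in compound 3; a stereocentre at a saturated ring carbon is drawn R in compound 2 and S in compound 3 and no atom or bond is altered. Among the measured compounds shown here, no measured pair isolates such an inversion, so the data give no direct size for this step. A step no larger than the scatter is expected, with no direction favoured. The estimate means an expected 1.1-fold lower number from compound 2 to compound 3 (0.05 log units; within the scatter) that stays inside that scatter. For compound 3 the expected value in this assay is 300 mL/min/kg with 140 mL/min/kg to 560 mL/min/kg as its estimated range.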

Compound 3, clearance: 167 mL/min/kg
For compound 3 the middle estimate is 1.8-fold (0.25 log units) above the measured one; low and high end bracket the measured number.
By their numbers in this assay, from the lowest: compounds 3, 1 and 2 (each within the scatter of the next).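

In this assay, among the compounds shown here, the series now has its first direct size for inverting all stereocentres, a 2.0-fold lower number from compound 2 to compound 3 (0.30 log units; within the scatter), and this single pair is the only reading of such an inversion. Since that step stays inside the scatter, the values give no firm preference for either mirror image, and compounds 2 and 3 are not ranked against each other. The comparison is a clean one, with no group entering or leaving, and it bears on configuration alone: the fact that compounds 2 and 3 differ only in the configuration as drawn

Still open, as far as these compounds go, is how inverting only one of the two stereocentres would read in this assay, since both change together here. Also open, from the compounds shown here alone, is whether an inversion would stay within the scatter with an amine or a carboxylic acid on the shared core in place of the trifluoromethoxy group.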